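Removing the Ethyl Group: Expected Cytotoxicity of Compound 4

This account rests on a few compounds, and the source may have more. Where it says the series, first, only, none or still open, it means among the compounds named here.

Three compounds built on one shared core were tested in an ADME assay on Vero cells (Chlorocebus sabaeus) for cytotoxicity, read by resazurin assay, with a stated time of 3 days; on this read-out lower numbers stand for stronger inhibition and higher numbers for weaker inhibition. Compound 1 `CN(C)c1cc2[nH]c(C3CCCCC3)nc2cc1NC(=O)OCC(F)(F)F` carries a 2,2,2-trifluoroethoxy group on its carbonyl carbon. In this assay compound 1 reaches only a limit of the assay, > 100 ug/mL. Compound 2 `CN(C)c1cc2[nH]c(C3CCCCC3)nc2cc1NC(=O)c1ccc(OC(F)F)cc1` bears a 4-(difluoromethoxy)phenyl group at that carbonyl carbon instead. In this assay compound 2 likewise gives a limit, > 100 ug/mL. Compound 3 `CCc1ccc(C(=O)Nc2cc3nc(C4CCCCC4)[nH]c3cc2N(C)C)cc1` has a 4-ethylphenyl group on the carbonyl carbon. In this assay compound 3 also stops at a limit, > 100 ug/mL. Compound 3 therefore stands exactly where the other two stand, with no cytotoxicity seen up to the top concentration tested. The sizes of the steps a step that the two limits leave unreadable from compound 1 to compound 2, a step that the two limits leave unreadable from compound 1 to compound 3 and a step that the two limits leave unreadable from compound 2 to compound 3 cannot be read, because all three values sit at the limit of > 100 ug/mL in this assay, at which 3 of the 3 values shown sit.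

Compound 4 `CN(C)c1cc2[nH]c(C3CCCCC3)nc2cc1NC(=O)c1ccccc1` differs from compound 3 by one change: hydrogen in place of ethyl on an aromatic carbon. Among the measured compounds shown here, no measured step reveals cytotoxicity appearing when the group on the carbonyl carbon is altered, and the present change is smaller than any of those. The step from compound 3 to compound 4 is therefore expected to be none beyond the scatter, a number no higher from compound 3 to compound 4 (the limit leaves the size open). Compound 4 is estimated at 100 ug/mL, within the range 50 ug/mL to 300 ug/mL, and most likely to be reported only as a limit again.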

Compound 4, half-maximal inhibitory concentration: > 100 ug/mL
Compound 4: a limit, no number; the forecaster's own chance of this, stated with the estimate: 85%; the middle value sits exactly at the limit.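

Among the compounds shown here, no step between compound 1, compound 2, compound 3 and compound 4 can be read in this assay, because all four stop at the same limit: the limit of > 100 ug/mL in this assay, at which 4 of the 4 values shown sit. The compounds shown leave open whether changing the group on the carbonyl carbon affects cytotoxicity at all, and at what concentration any of the four would show it.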